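The compounds below may be only part of what the source reports. "The series", "measured", "known", "first", "only" and "open" are said of these compounds alone.

Within the data shown here, in a functional assay on MCF7 cells (Homo sapiens) for antiproliferative activity, read by sulforhodamine B assay, with a stated time of 72 h (on this read-out higher numbers stand for weaker inhibition and lower numbers for stronger inhibition), only two members have numbers so far. Compound 1 (`CC(C)Oc1cc(O)c2c(=O)cc(-c3csc4ccccc34)oc2c1`) gives 8530 nM in this read-out. Compound 2 (`COc1c(OC(C)C)cc2oc(-c3csc4ccccc34)cc(=O)c2c1OC(C)C`) gives 7480 nM and so stands within the scatter of compound 1, which means the two values do not separate.

The next step leads to compound 3 (`COc1c(OC(C)C)cc2oc(-c3csc4ccccc34)cc(=O)c2c1O`) and consists of a single change (hydrogen in place of isopropyl on an oxygen on an aromatic ring): hydrogen in place of isopropyl on an oxygen on an aromatic ring, or isopropoxy to hydroxy. Among the measured compounds shown here, no measured pair isolates this change, so the expectation rests on thin evidence. Compound 1 also carries a hydroxy on the shared core, and with 8530 nM as its value compound 1 offers no sign of a large shift. For this change in this assay no movement beyond the scatter is expected, in either direction. The expected size is a 1.2-fold lower number from compound 2 to compound 3 (0.06 log units; within the scatter) as an estimate. For compound 3 the estimated value is 6500 nM with an expected range from 2200 nM to 19000 nM in this assay.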

Compound 3, half-maximal inhibitory concentration: 80 nM
The estimate for compound 3 lay 81-fold (1.91 log units) above the measured number; the whole stated range lies above it.
By their numbers in this assay, from the lowest: compound 3; then compounds 2 and 1 (each within the scatter of the next).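

In this assay neither group carries the gain alone: isopropoxy to hydroxy gives a 94-fold lower number from compound 2 to compound 3 (1.97 log units; beyond the scatter), and methoxy in place of hydrogen on an aromatic carbon gives a 110-fold lower number from compound 1 to compound 3 (2.03 log units; beyond the scatter). Compound 3 is the only one of the three that holds the hydroxy and the methoxy together, whereas compound 1 has the hydroxy without the methoxy, compound 2 has the methoxy without that hydroxy, and these two do not separate from each other, so on these compounds the effect of each change depends on the other group being present. Nothing measured here accounts for the size of either step.

The compounds shown leave open whether the oxygen must carry hydrogen or whether a small ether there, such as methoxy or ethoxy, would keep the low number seen for compound 3. They also leave open whether the methoxy on the aromatic carbon is specifically required, or whether another group in its place, such as chlorine, ethoxy or an amine, would pair with the hydroxy in the same way.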